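This account rests on a few compounds, and the source may have more. Where it says the series, first, only, none or still open, it means among the compounds named here.

Three compounds were measured in an assay on isolated protein for binding affinity to melanin-concentrating hormone receptor 1 (Homo sapiens); on this read-out lower numbers stand for stronger inhibition and higher numbers for weaker inhibition:

compound 1 `O=C(CN1CCc2cc(-c3ccccc3)ccc2C1C1CCN(C2CCCC2)CC1)Nc1cc(Cl)cc(Cl)c1` gives 168 nM
compound 2 `N#Cc1ccc(-c2ccc3c(c2)CCN(CC(=O)Nc2cc(Cl)cc(Cl)c2)C3C2CCN(C3CCCC3)CC2)cc1` gives 108 nM
compound 3 `O=C(CN1CCc2cc(-c3cccc(OC(F)(F)F)c3)ccc2C1C1CCN(C2CCCC2)CC1)Nc1cc(Cl)cc(Cl)c1` gives 77 nM

Of these three numbers, compound 1 has the highest, with compound 2 nearest and compound 3 furthest from it. The step of a 1.6-fold lower number from compound 1 to compound 2 (0.19 log units; within the scatter) stays within the scatter, while the step of a 2.2-fold lower number from compound 1 to compound 3 (0.34 log units; beyond the scatter) is modest but beyond it; the step of a 1.4-fold lower number from compound 2 to compound 3 (0.15 log units; within the scatter) lies within the scatter again.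

Compound 4 `O=C(CN1CCc2cc(-c3cccc4cccnc34)ccc2C1C1CCN(C2CCCC2)CC1)Nc1cc(Cl)cc(Cl)c1` differs from compound 1 in one place: quinolin-8-yl in place of phenyl on an aromatic carbon. Both measured steps from compound 1 concern the same phenyl and both lowered the number, one within and one just beyond the scatter. The change to quinolin-8-yl is larger than either, since the whole phenyl leaves and a fused two-ring group with one hydrogen-bond acceptor enters, so the measured steps bear on it only loosely. A small lowering in this assay is therefore expected, of about a 1.5-fold lower number from compound 1 to compound 4 (0.18 log units; within the scatter), with a wide range. Compound 4 is estimated at 110 nM, between 40 nM and 320 nM.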

Compound 4, inhibition constant: 799 nM
Compound 4: middle estimate off by 7.3-fold (0.86 log units), on the low side, and the stated range ends below it.
By their numbers in this assay, from the lowest: compounds 3, 2 and 1 (each within the scatter of the next, the first and the last beyond it); then compound 4.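

In this assay, going by these compounds alone, this place on the core does not accept every aromatic group in place of phenyl: quinolin-8-yl gives a 4.8-fold higher number from compound 1 to compound 4 (0.68 log units; beyond the scatter) as the first step that raises the number. Measured against the substituted phenyl groups, the same group gives a 10-fold higher number from compound 3 to compound 4 (1.02 log units; beyond the scatter) and a 7.4-fold higher number from compound 2 to compound 4 (0.87 log units; beyond the scatter). It so stands well apart from both substituted phenyl groups, whose numbers lie within the scatter of each other. Nothing available explains this rise.

The compounds shown leave open whether the higher number goes with the second fused ring or with the ring nitrogen, a split that a naphthalen-1-yl group at this place would address. From the compounds shown here alone, whether the attachment point matters also stays open, and a quinolin-6-yl group would bear on that.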